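Chain methylation on the phenylpiperazine succinimide amide series

This account rests on a few compounds, and the source may have more. Where it says the series, first, only, none or still open, it means among the compounds named here.

Measured compounds:
compound 1 `CC(C(=O)N1CCN(c2ccccc2)CC1)N1C(=O)CCC1=O` — 50%
compound 2 `CC(C(=O)N1CCN(c2cccc(C(F)(F)F)c2)CC1)N1C(=O)CCC1=O` — 100%
compound 3 `Cc1cccc(N2CCN(C(=O)C(C)N3C(=O)CCC3=O)CC2)c1` — 50%

Three compounds have been run in a functional assay on the whole organism (strain Swiss) with Mus musculus as the target, in the maximal electroshock model, with a stated time of 0.5 h, at a dose of 300 mg/kg by the intraperitoneal route (on this read-out lower numbers stand for a weaker effect and higher numbers for a stronger effect at the one dose given), and they differ only in what sits on one aromatic carbon of the shared core. Compound 1 carries hydrogen there and stands level with compound 3, which carries methyl: no change at the digits printed from compound 1 to compound 3 (within the scatter). Against compound 2, which carries trifluoromethyl, compound 1 sits well under: a number 50 percentage points higher from compound 1 to compound 2 (beyond the scatter). The reverse comparison runs a number 50 percentage points lower from compound 2 to compound 3 (beyond the scatter). So the only change seen to move this read-out beyond the scatter is the one that brings trifluoromethyl onto the aromatic carbon; hydrogen and methyl there give the same number.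

Compound 4 `CCC(C(=O)N1CCN(c2ccccc2)CC1)N1C(=O)CCC1=O` keeps the unsubstituted aromatic ring of compound 1 and differs from it by
methyl in place of hydrogen on a saturated chain carbon, two bonds along the chain from an amide-type nitrogen in a ring and a carbonyl carbon
Not one of the three measured steps touches the saturated chain; all three sit on the aromatic carbon, so none of them bears directly on this change. No information on the chain position is in hand. The expectation is therefore a step of no size beyond the scatter, no change at the digits printed from compound 1 to compound 4 (within the scatter). For compound 4 the estimated value in this assay is 50%, with a range from 25% to 80%.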

Compound 4, a percentage reported as activity, at one dose (the size of the read-out at that dose, not a potency): 75%
For compound 4 the middle estimate is 25 percentage points below the measured one; measured number inside the range.
By their numbers in this assay, from the lowest: compounds 1 and 3 (each within the scatter of the next); then compound 4; then compound 2.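

In this assay the saturated chain carbon emerges as a second place where a change moves the read-out beyond the scatter: a number 25 percentage points higher from compound 1 to compound 4 (beyond the scatter) for methyl in place of hydrogen, read on the chain as methyl to ethyl. Until now, only trifluoromethyl on the aromatic carbon had produced a step beyond the scatter, and the same exchange of hydrogen for methyl on that aromatic carbon gave no change at the digits printed from compound 1 to compound 3 (within the scatter) in this read-out, so the outcome of adding methyl to the core of compound 1 differs between these two places. No measured information accounts for the chain step, and it stands here only as a difference in the read-out at the one dose given.

Still open, on these data alone, is whether the chain read-out keeps rising with a propyl or butyl group at this carbon, or changes with a hydroxymethyl or phenyl group there. Also open, as far as these compounds go, is whether ethyl in place of methyl on the chain gives a comparable step when the aromatic ring carries trifluoromethyl or methyl, as in the cores of compound 2 and compound 3.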